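The compounds below may be only part of what the source reports. "The series", "measured", "known", "first", "only" and "open" are said of these compounds alone.

Two esters built on one shared core have been measured. Compound 1, `CC(=O)Oc1ccccc1C(=O)O[C@H]1CO[C@H]2[C@@H]1OC[C@H]2OC(=O)c1ccccc1O`, and compound 2, `CC(=O)Oc1ccccc1C(=O)O[C@H]1CO[C@H]2[C@@H]1OC[C@H]2OC(=O)c1ccc([N+](=O)[O-])cc1`, differ only in the aryl group attached to one carbonyl carbon. In an ADME assay on a cell-free system (plasma, Homo sapiens) for metabolic stability, with Plasma (Rattus norvegicus) as the target, read by HPLC, at pH 7.4 (on this read-out lower numbers stand for a shorter-lived compound and higher numbers for a longer-lived compound), compound 1 gives 0.019 h, and compound 2 gives 0.0227 h. Among the measured compounds shown here, the single step between them, a 1.2-fold higher number from compound 1 to compound 2 (0.08 log units; within the scatter), is the only one that bears on the next change. On these two numbers compound 2 has the higher value, but the gap to compound 1 sits within the scatter, so the two cannot be told apart.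

Compound 3, `CC(=O)Oc1ccccc1C(=O)O[C@H]1CO[C@H]2[C@@H]1OC[C@H]2OC(=O)c1ccc(-c2ccccc2)cc1`, keeps the whole of compound 2 except for one exchange: phenyl in place of nitro on an aromatic carbon. For the measured compounds named here, since the one measured exchange at the same carbonyl produced nothing beyond the scatter, no step beyond the scatter is expected here either, with at most a slight lean toward a longer-lived compound.

For compound 3 the expected half-life in this assay is therefore 0.025 h, within a range from 0.012 h to 0.06 h, which corresponds to an expected step of a 1.1-fold higher number from compound 2 to compound 3 (0.04 log units; within the scatter).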

Compound 3, half-life: > 0.333 h
Compound 3 gave a limit, no number (the forecaster's own chance of this, stated with the estimate: 5%); at least 13-fold (1.12 log units) between middle value and limit.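

Compound 3 gave a limit of the assay and not a number: the limit of > 0.333 h in this assay, at which 1 of the 3 values shown sits.

Even so, the exchange of nitro for phenyl, on an aromatic carbon para to a large group, does something the earlier pair did not show: this assay gives an at least 14-fold higher number from compound 2 to compound 3 (1.16 log units; beyond the scatter), while the one earlier exchange at this carbonyl stayed within the scatter, at a 1.2-fold higher number from compound 1 to compound 2 (0.08 log units; within the scatter). The comparison with the first ester points the same way, with an at least 17-fold higher number from compound 1 to compound 3 (1.24 log units; beyond the scatter), so a single change in the aryl group on this carbonyl can move the half-life far more than the first two compounds suggested.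

Going by these compounds, how long compound 3 really lasts stays open. Also open, on these data alone, is whether the large step belongs to phenyl in particular or would also appear with another group on the same aromatic carbon, such as an amine, a carboxylic acid or a longer chain.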